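A few compounds are considered here, and "the series" means these few. Any claim that something is new, unique, unknown or untested is made for them only; others in the source may bear on it.

Compound 1 `Cc1nn(-c2ncnc3nc[nH]c23)c2c1C(OCCc1ccccc1)CC(=O)N2`: 3 nM
Compound 2 `O=C1/C(=C/NCCCO)C(c2ccccc2)=NN1c1nc2ccccc2s1`: 200 nM

Of the compounds shown here, two have been measured in a functional assay on HEK293 cells for agonist activity at G-protein coupled receptor 39 (Homo sapiens), read by scintillation proximity assay and inositol phosphate accumulation, with a stated time of 75 min, in the presence of a further agent that is not named here; a lower number here means that less compound is needed, a higher number that more compound is needed for the effect. Compound 1 gives 3 nM, the lower of the two numbers. Compound 2, built on a different core, gives 200 nM in this assay, a much higher number that lies well beyond the scatter of repeated measurements; no single-point comparison links these two compounds.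

Compound 3 `Cc1nn(-c2ncnc3nc[nH]c23)c2c1C(OC(=O)c1ccc(F)cc1)CC(=O)N2` keeps the core of compound 1 and changes one group: (4-fluorophenyl)carbonyl in place of phenethyl on an oxygen on a saturated carbon. The flexible two-carbon linker to the phenyl ring is replaced by a carbonyl bearing a fluorinated phenyl ring, so the oxygen now sits in an ester rather than an ether.

Among the measured compounds shown here, no measured pair shows what such a change does here. With compound 1 at 3 nM, compound 3 is expected to give a somewhat higher number in this assay, an estimated step of a 5.0-fold higher number from compound 1 to compound 3 (0.70 log units; beyond the scatter). Compound 3 is thus estimated at 15 nM, within a range from 3 nM to 80 nM.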

Compound 3, half-maximal effective concentration: 4 nM
Beside the measured number, compound 3's estimate is 3.8-fold (0.57 log units) above it; measured number inside the range.
By their numbers in this assay, from the lowest: compounds 1 and 3 (each within the scatter of the next); then compound 2.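

In this assay the change gives a 1.3-fold higher number from compound 1 to compound 3 (0.12 log units; within the scatter) and so this position on the shared core tolerates two quite different groups without a difference that stands out from the usual scatter of repeated measurements. The oxygen on a saturated carbon can carry (4-fluorophenyl)carbonyl, which holds a carbonyl and a fluorine, as well as phenethyl, which is made of carbon only. Nothing available explains why these two groups give such similar numbers.

From the compounds shown here alone, what the carbonyl and the fluorine each contribute alone stays open, for instance what a phenyl ring without fluorine would give on the same carbonyl. Also open, going by these compounds, is how this oxygen would fare with a group of another kind, such as an amine or a carboxylic acid at the end of a longer chain.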